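A few compounds are considered here, and "the series" means these few. Any claim that something is new, unique, unknown or untested is made for them only; others in the source may bear on it.

Measured so far in an assay on Sf9 cells for inhibition of protein deacetylase HDAC6 (Homo sapiens), read by fluorescence, with a stated time of 40 min, tested at 100 nM; on this read-out higher numbers stand for more inhibition at the one concentration tested (going by the name of the read-out) and lower numbers for less inhibition:
- compound 1 `Cc1ccc(-c2nc(CNc3ccc(C(=O)NO)cc3)n(-c3ccccc3)n2)o1` gives 60.7%
- compound 2 `O=C(NO)c1ccc(NCc2nc(-c3cccnc3)nn2-c2ccccc2)cc1` gives 57.7%
- compound 3 `O=C(NO)c1ccc(NCc2nc(-c3ccc(Br)o3)nn2-c2ccccc2)cc1` gives 55.8%

Compound 3 has the lowest of the three numbers, but its distance to compound 2 and to compound 1 is within the scatter in each case, so the three compounds cannot be ranked against one another on these readings.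

The next compound, compound 4 `O=C(NO)c1ccc(NCc2nc(-c3ccsc3)nn2-c2ccccc2)cc1`, has not yet been measured in this assay. It differs from compound 3 in one place: thiophen-3-yl in place of 5-bromofuran-2-yl on an aromatic carbon. The group sits where the three measured compounds already vary. Within the data shown here, the steps that bear on it are a number 1.9 percentage points lower from compound 2 to compound 3 (within the scatter), which exchanges the group at that position, a number 3 percentage points lower from compound 1 to compound 2 (within the scatter), which also exchanges it, and a number 4.9 percentage points lower from compound 1 to compound 3 (within the scatter), which alters only the substituent on the furan. All three steps are within the scatter, so the readings so far give no sign that this position moves the read-out in either direction.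

Compound 4 is therefore expected to give 57%, in a range from 45% to 69%. The step of a number 1.2 percentage points higher from compound 3 to compound 4 (within the scatter) implied by this estimate is expected to stay within the scatter.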

Compound 4, a percentage reported as inhibition, at one concentration (the size of the read-out at that concentration, not a potency): 53.4%
Compound 4: the middle estimate sits 3.6 percentage points above what was measured; the measured number falls inside the stated range.
By their numbers in this assay, from the lowest: compounds 4, 3, 2 and 1 (each within the scatter of the next).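

In this assay, thiophen-3-yl on the aromatic carbon between two ring nitrogen atoms adds a sulfur-containing ring to the groups seen at this position, and all three new comparisons stay level: a number 2.4 percentage points lower from compound 3 to compound 4 (within the scatter), a number 4.3 percentage points lower from compound 2 to compound 4 (within the scatter) and a number 7.3 percentage points lower from compound 1 to compound 4 (within the scatter). The exchange for 5-bromofuran-2-yl removes the bromine and replaces the ring oxygen with a ring sulfur, yet the reading does not move beyond the scatter, so across these four compounds neither the bromine nor the ring oxygen shows any separate effect on the read-out at the one concentration tested. No supporting measurement bears on why these groups read alike.

From the compounds shown here alone, all four groups at this position are five- or six-membered aromatic rings, so it remains open whether a non-aromatic group, such as an amine like morpholine, a carboxylic acid or a longer alkyl chain, would give a reading beyond the scatter. The phenyl group on the ring nitrogen is also common to all four compounds, which leaves open what a saturated group such as cyclohexyl would do there.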